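The compounds below may be only part of what the source reports. "The series", "measured", "known", "first", "only" and "open" are said of these compounds alone.

Working notes on the series. Compound 1 `CCCC#Cc1cc([C@@H]2O[C@H](CO)[C@@H](O)[C@H]2O)n2ncnc(N)c12` and compound 2 `Nc1ncnn2c([C@@H]3O[C@H](CO)[C@@H](O)[C@H]3O)cc(C#Cc3cccs3)c12` share one core and differ only at the group on the triple-bonded carbon. In a functional assay on HL-60 cells (Homo sapiens) for antiproliferative activity, with a stated time of 72 h (on this read-out higher numbers stand for weaker inhibition and lower numbers for stronger inhibition), compound 1 gives 200 nM. For compound 2 this assay reports only a limit, > 100000 nM, not a number. The step is an at least 500-fold higher number from compound 1 to compound 2 (2.69 log units; beyond the scatter); its true size is not known, because the limit of > 100000 nM in this assay, at which 1 of the 2 values shown sits, caps what can be read from it.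

Compound 3 `Cc1ccccc1-c1cc([C@@H]2O[C@H](CO)[C@@H](O)[C@H]2O)n2ncnc(N)c12` is not yet measured. Against compound 2 the change is 2-methylphenyl in place of 2-(thiophen-2-yl)ethynyl on an aromatic carbon. No measured step touches this position in the same way: the one step shown changes the group on the triple-bonded carbon, whereas here the triple bond itself leaves together with the ring on it. That step therefore bears only indirectly. It shows that a sizeable aromatic group at the end of the alkyne is poorly tolerated, while the shorter propyl chain of compound 1 is not. Compound 3 carries its aromatic ring without the linker, so some recovery toward the number of compound 1 is expected, though a limit remains possible. For compound 3 an estimated step of an at least 20-fold lower number from compound 2 to compound 3 (1.30 log units; beyond the scatter) is expected, with a value of 5000 nM between 300 nM and 100000 nM.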

Compound 3, half-maximal inhibitory concentration: 48400 nM
Compound 3: middle estimate off by 9.7-fold (0.99 log units), on the low side; the measured number falls inside the stated range.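

In this assay, compound 3 gives a number at this aromatic carbon, where the 2-(thiophen-2-yl)ethynyl group gave only a limit, and the exchange reads as an at least 2.0-fold lower number from compound 2 to compound 3 (0.31 log units; beyond the scatter). This step is only a lower bound on the true change, because one end of it is not a number: the limit of > 100000 nM in this assay, at which 1 of the 3 values shown sits. The comparison with the pent-1-yn-1-yl group sets a second reference, a 240-fold higher number from compound 1 to compound 3 (2.38 log units; beyond the scatter), so at this position a 2-methylphenyl group carried directly on the shared core, with no triple bond, does not return the series to the level of compound 1.

On these data alone, what an unsubstituted phenyl, a cyclohexyl ring or a longer alkyl chain on the triple bond would give at this carbon stays open. Among the compounds shown here, the series also cannot yet separate the contribution of the triple bond from that of the aromatic ring, as compound 2 and compound 3 both carry an aromatic ring and compound 1 is the only member with an alkyl chain.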